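Halogen swap on the pendant phenyl of compound 3

The compounds below may be only part of what the source reports. "The series", "measured", "known", "first", "only" and "open" are said of these compounds alone.

Measured so far in a functional assay on SK-MEL-5 cells (Homo sapiens) for inhibition, read by sulforhodamine B assay, with a stated time of 48 h, tested at 10 uM; a higher number here means more inhibition at the concentration tested (going by the name of the read-out), a lower number less inhibition:
compound 1, `Brc1cn2ccnc2c(-c2ccc3ncn(C4CCCCC4)c3c2)n1`: 13.4%
compound 2, `c1ccc(-c2cn3ccnc3c(-c3ccc4ncn(C5CCCCC5)c4c3)n2)cc1`: 36.5%
compound 3, `Clc1ccc(-c2cn3ccnc3c(-c3ccc4ncn(C5CCCCC5)c4c3)n2)cc1`: 12.4%

Compound 3 gives the lowest of the three numbers in this assay, though its distance to compound 1 lies within the scatter; only compound 2 sits clearly apart, the step being a number 24.1 percentage points lower from compound 2 to compound 3 (beyond the scatter). The other steps read a number 23.1 percentage points higher from compound 1 to compound 2 (beyond the scatter) and a number 1 percentage points lower from compound 1 to compound 3 (within the scatter), so the unsubstituted phenyl stands out while bromo on the shared core and 4-chlorophenyl are indistinguishable here.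

Compound 4, `Brc1ccc(-c2cn3ccnc3c(-c3ccc4ncn(C5CCCCC5)c4c3)n2)cc1`, is the next member. It differs from compound 3 by bromo in place of chloro on an aromatic carbon. Going by the values given here, no measured step exchanges one halogen for another on this ring; the only step touching this ring, a number 24.1 percentage points lower from compound 2 to compound 3 (beyond the scatter), concerns chloro entering in place of hydrogen, and it is modest. A swap of chloro for bromo is a smaller change than that, so no step beyond the scatter is expected in this assay, in either direction.

Compound 4 is therefore estimated at 15%, in the range 2% to 32%, an expected step of a number 2.6 percentage points higher from compound 3 to compound 4 (within the scatter).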

Compound 4, a percentage reported as inhibition, at one concentration (the size of the read-out at that concentration, not a potency): 23.6%
Estimate against measurement, compound 4: 8.6 percentage points below, and the stated range covers the measured number.
By their numbers in this assay, from the lowest: compounds 3 and 1 (each within the scatter of the next); then compound 4; then compound 2.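

In this assay, going by these compounds alone, the two halogens on the pendant ring do not read alike: a number 11.2 percentage points higher from compound 3 to compound 4 (beyond the scatter) gives the first exchange of one halogen for another here, a modest step. Neither halogen matches the unsubstituted ring, since a number 12.9 percentage points lower from compound 2 to compound 4 (beyond the scatter) adds to the earlier loss seen with chloro, and compound 2 keeps the highest number of the four. The 4-bromophenyl group also separates from bromo on the shared core, with a number 10.2 percentage points higher from compound 1 to compound 4 (beyond the scatter), whereas 4-chlorophenyl did not; no measurement available accounts for the difference between chloro and bromo.

With hydrogen, chloro and bromo as the only substituents shown at this position, the numbers do not follow the order of halogen size: compound 3, with chloro, lies below compound 4, with bromo, yet compound 2, with hydrogen, lies above both, so fluoro, iodo, methyl or methoxy could each fall anywhere relative to these values. Each number also comes from a single concentration, which leaves open whether these modest steps would carry over to potency, and whether an amine or a carboxylic acid on this ring would restore the level of compound 2.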